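Swapping methoxy for chloro on a sulfonamide

This account rests on a few compounds, and the source may have more. Where it says the series, first, only, none or still open, it means among the compounds named here.

Compound 1 `COc1ccc(S(=O)(=O)Nc2cccc3cc(Cl)[nH]c23)cc1`: 0.12 ug/mL
Compound 2 `COc1ccc(S(=O)(=O)Nc2cccc3c(Cl)c[nH]c23)cc1`: 0.55 ug/mL
Compound 3 `O=S(=O)(Nc1cccc2cc(Cl)[nH]c12)c1ccc(Cl)cc1`: not yet measured

Going by the values given here, in a functional assay on KB cells (Homo sapiens) for antiproliferative activity, read by colorimetric assay and MTT assay (a higher number here means a weaker inhibitor, a lower number a stronger inhibitor), compound 1 gives 0.12 ug/mL, the lower of the two numbers so far, which makes it the stronger inhibitor of the pair. Compound 2, at 0.55 ug/mL, stands apart from it by more than the usual scatter of repeated measurements.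

Compound 3 keeps the core of compound 1 and differs in one place: chloro in place of methoxy on an aromatic carbon, para to a large group (chloro in place of methoxy on an aromatic carbon). Among the compounds with values here, no measured pair shows what this swap does, since compound 1 and compound 2 both carry the methoxy group. The expectation is therefore loose: a modest move toward a higher number, meaning a somewhat weaker inhibitor. The step expected is a 2.1-fold higher number from compound 1 to compound 3 (0.32 log units; beyond the scatter). For compound 3 the estimated value is 0.25 ug/mL, with an expected range of 0.07 ug/mL to 0.9 ug/mL.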

Compound 3, half-maximal inhibitory concentration: 4 ug/mL
For compound 3 the middle estimate is 16-fold (1.20 log units) below the measured one, and the stated range ends below it.
By their numbers in this assay, from the lowest: compound 1; then compound 2; then compound 3.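

In this assay, the group on the aromatic carbon para to a large group proves to matter a great deal: chloro in place of methoxy gives a 33-fold higher number from compound 1 to compound 3 (1.52 log units; beyond the scatter) and so a much weaker inhibitor, a large change well beyond the scatter. The earlier pair could not show this, since both of its members carry the methoxy group and differ only in where the chlorine sits on the shared core. This one swap replaces a two-atom group that counts as a hydrogen-bond acceptor with a single chlorine atom that does not, yet no measurement available here explains why the step is so large.

The compounds shown do not settle which feature of methoxy counts, and a hydroxyl, an amine or a plain methyl at the same place would help to separate the role of its oxygen from that of its size. They also leave open whether the same swap would carry a similar penalty on the core of compound 2, as this step rests on a single pair.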